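Swapping a Sulfonyl for a Chloropyridine Amide

The source may hold more compounds than are shown below. What is called first, only, known or untested is meant among the compounds shown, and "the series" means these compounds.

Of the compounds shown here, three built on a shared core have been tested in an assay on cells for inhibition of cytochrome P450 11B2, mitochondrial (Homo sapiens), read by HTRF; a lower number here means a stronger inhibitor, a higher number a weaker inhibitor. Compound 1 `C[C@@H](NS(C)(=O)=O)c1cncc(N2C(=O)c3ccc(Cl)cc3C2(C)C)c1` gives 8 nM, compound 2 `CCS(=O)(=O)N1CC(Oc2cncc(N3C(=O)c4ccc(Cl)cc4C3(C)C)c2)C1` gives 4 nM, and compound 3 `CCC(=O)N[C@@H]1CCCc2c1cncc2N1CCc2cc(Cl)ccc2C1=O` gives 119 nM. The numbers of compound 2 and compound 1 lie within the usual scatter of each other, so the two cannot be told apart, whereas compound 3 stands far off from compound 2, a gap well beyond the scatter. Compound 4 `CC1(C)c2cc(Cl)ccc2C(=O)N1c1cncc(OC2CN(C(=O)c3ncccc3Cl)C2)c1` has not yet been measured in this assay. Among the compounds with values here, it differs from compound 2 in one place: (3-chloropyridin-2-yl)carbonyl in place of ethylsulfonyl on an amine nitrogen in a ring No measured pair shows an exchange of this kind, so what is expected of compound 4 rests only on the values of the three measured compounds and on the change itself. A modest step is expected, a 2.0-fold higher number from compound 2 to compound 4 (0.30 log units; within the scatter), with no direction that would clearly exceed the scatter. Compound 4 is therefore estimated at 8 nM, in a range from 2 nM to 30 nM.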

Compound 4, half-maximal inhibitory concentration in the cytochrome P450 11B2, mitochondrial assay: 5 nM
Estimate against measurement, compound 4: 1.6-fold (0.20 log units) above, within the range that was stated.
By their numbers in the cytochrome P450 11B2, mitochondrial assay, from the lowest: compounds 2, 4 and 1 (each within the scatter of the next); then compound 3.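

The nitrogen of the four-membered ring accepts a larger group that carries an aromatic ring without any measurable loss of inhibition: in the cytochrome P450 11B2, mitochondrial assay, exchanging ethylsulfonyl for (3-chloropyridin-2-yl)carbonyl gives a 1.3-fold higher number from compound 2 to compound 4 (0.10 log units; within the scatter), so the two compounds cannot be told apart. The exchange does show up in a second property, since in a physicochemical assay for solubility, in phosphate buffer, with a stated time of 2 h, at pH 6.5 (on this read-out higher numbers stand for higher solubility and lower numbers for lower solubility), compound 2 gives 78 ug/mL and compound 4 gives 20 ug/mL. At this position, then, inhibition stays in place while solubility falls with the exchange: the measured solubility of compound 2, 78 ug/mL, and of compound 4, 20 ug/mL, a 3.9-fold lower number (0.59 log units; beyond the scatter)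

Going by these compounds, it remains open whether an acetyl or a benzoyl group on this nitrogen would hold inhibition and also keep the solubility of compound 2. What the chlorine on the pyridine contributes to either read-out is also unresolved.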